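This account rests on a few compounds, and the source may have more. Where it says the series, first, only, none or still open, it means among the compounds named here.

Measured in an assay on isolated protein (strain Sprague-Dawley) for inhibition of Amine oxidase [flavin-containing] B (Rattus norvegicus), read by spectrophotometry, with a stated time of 5 min; a higher number here means a weaker inhibitor, a lower number a stronger inhibitor:
compound 1 `CCOC(=O)COc1cc(=O)oc2cc(OCc3cccc(Cl)c3)ccc12` gives 1820 nM
compound 2 `O=c1cc(Cl)c2ccc(OCc3cccc(Cl)c3)cc2o1` gives 20.9 nM
compound 3 `O=c1cc(CO)c2ccc(OCc3cccc(Cl)c3)cc2o1` gives 5.25 nM

Compound 3 gives the lowest of the three numbers; the nearest is compound 2, with a 4.0-fold lower number from compound 2 to compound 3 (0.60 log units; beyond the scatter), and the furthest is compound 1, with a 350-fold lower number from compound 1 to compound 3 (2.54 log units; beyond the scatter). Compound 4 `O=Cc1cc(=O)oc2cc(OCc3cccc(Cl)c3)ccc12` differs from compound 3 by formyl in place of hydroxymethyl on an aromatic carbon. Going by the values given here, no measured step swaps formyl for hydroxymethyl. Among the compounds with values here, the exchanges seen at this carbon were an 87-fold lower number from compound 1 to compound 2 (1.94 log units; beyond the scatter) and a 4.0-fold lower number from compound 2 to compound 3 (0.60 log units; beyond the scatter), the latter being the only exchange between two small groups and only modest. Within the data shown here, with no closer precedent, a step in this assay no larger than that modest one is expected, in either direction. Compound 4 is therefore estimated at 7 nM, with a range of 2 nM to 25 nM, which means an expected step of a 1.3-fold higher number from compound 3 to compound 4 (0.12 log units; within the scatter).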

Compound 4, half-maximal inhibitory concentration: 52.5 nM
For compound 4 the middle estimate is 7.5-fold (0.88 log units) below the measured one, and the stated range ends below it.
By their numbers in this assay, from the lowest: compound 3; then compound 2; then compound 4; then compound 1.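

In this assay this position separates even two groups of equal heavy-atom count: with formyl in place of hydroxymethyl, there is a 10-fold higher number from compound 3 to compound 4 (1.00 log units; beyond the scatter) and the hydrogen-bond donor is lost. Formyl also trails chloro, with a 2.5-fold higher number from compound 2 to compound 4 (0.40 log units; beyond the scatter) as the step, but stays well ahead of (ethoxycarbonyl)methoxy, with a 35-fold lower number from compound 1 to compound 4 (1.54 log units; beyond the scatter) as the step. No evidence on hand accounts for these steps.

On these data alone, whether the donor itself matters remains open. An aminomethyl or methoxymethyl group on this carbon would bear on that question.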